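This account rests on a few compounds, and the source may have more. Where it says the series, first, only, none or still open, it means among the compounds named here.

Compound 1, `N#Cc1c(N)c(Cl)c2nc(N)nc(N)c2c1Cl`, gives 188 ug/mL in a functional assay on A549 cells (Homo sapiens) for cytotoxicity, read by MTT assay; a lower number here means a stronger inhibitor, a higher number a weaker inhibitor. Compound 2, `N#Cc1c(Nc2ccccc2)c(Cl)c2nc(N)nc(N)c2c1F`, reaches only the limit > 1000 ug/mL in this assay. Compound 3, `N#Cc1c(Nc2ccccc2)c(F)c2nc(N)nc(N)c2c1F`, likewise reaches only the limit > 1000 ug/mL in this assay.

Compound 3 therefore stands at the limit, not at a number; the step that the two limits leave unreadable from compound 2 to compound 3 cannot be read, because of the limit of > 1000 ug/mL in this assay, at which 2 of the 3 values shown sit. Compound 4, `N#Cc1c(NCc2ccccc2)c(F)c2nc(N)nc(N)c2c1F`, differs from compound 3 by benzyl in place of phenyl on a nitrogen on an aromatic ring. No measured step among the compounds shown bears on this change, so no size or direction can be inferred for it in this assay. Compound 4 is expected to sit near the limit as well, with an estimated 1000 ug/mL (range 300 ug/mL to 2000 ug/mL), which is the expected step of a number no higher from compound 3 to compound 4 (the limit leaves the size open).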

Compound 4, half-maximal inhibitory concentration: > 1000 ug/mL
Compound 4: only a limit was reported; the forecaster's own chance of this, stated with the estimate: 70%; the middle value sits exactly at the limit.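

Compound 4 gives only a limit, > 1000 ug/mL, and compound 3 also stands at a limit, so no step can be read between them. The compounds shown leave open what the anilino to benzylamino change does in this assay.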